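Dropping the Amino Group: Compound 2 to Compound 3

The source may report more compounds than this note shows. Statements on the series, on what has been measured and on what is new or still open speak of the compounds shown alone.

Of the compounds shown here, two have been tested in a functional assay on CAKI-1 cells (Homo sapiens) for cytotoxicity, read by sulforhodamine B assay, with a stated time of 48 h; a lower number here means a stronger inhibitor of growth, a higher number a weaker inhibitor of growth. Compound 1 `ClCc1cccc(Cn2cnc3c(Cl)nc(Cl)nc32)c1` gives 5880 nM. Compound 2 `Nc1nc(Cl)c2ncn(Cc3ccccc3CCl)c2n1` gives 20400 nM, the highest of the two numbers and beyond the scatter from compound 1, so it is the weaker growth inhibitor of the pair. Compound 3 `ClCc1ccccc1Cn1cnc2c(Cl)ncnc21` is the next candidate and differs from compound 2 in one place: hydrogen in place of amino on an aromatic carbon. Within the data shown here, no measured pair shows this change, so its effect in this assay is uncertain; a modest step in either direction, or none beyond the scatter, is plausible. Compound 3 is expected to give about 12000 nM, most likely within 4000 nM to 35000 nM. That estimate amounts to an expected step of a 1.7-fold lower number from compound 2 to compound 3 (0.23 log units; within the scatter).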

Compound 3, concentration for total growth inhibition: 4170 nM
Compound 3: middle estimate off by 2.9-fold (0.46 log units), on the high side; measured number inside the range.
By their numbers in this assay, from the lowest: compounds 3 and 1 (each within the scatter of the next); then compound 2.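

In this assay, among these compounds, the swap of amino for hydrogen on the aromatic carbon between two ring nitrogen atoms gives a 4.9-fold lower number from compound 2 to compound 3 (0.69 log units; beyond the scatter) and so offers the first one-place comparison here. Growth inhibition at this position does not depend on keeping the amino group, at least in this single pair. Nothing measured here explains the shift.

Still open, on these data alone, is what other groups on this carbon would do, such as methyl, methoxy or a dimethylamine. One pair also cannot show whether the step would hold on a different core.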